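Carboxy to methylcarbamoyl at the chain end of compound 1

The source may hold more compounds than are shown below. What is called first, only, known or untested is meant among the compounds shown, and "the series" means these compounds.

Measured so far:
compound 1 `O=C(O)COc1ccncc1-c1ccc2ccccc2c1` — 16%
compound 2 `O=C(/C=C/c1ccncc1-c1ccc2cccnc2c1)N1CCOCC1` — 33%

Two compounds carry numbers in an assay on a protein complex for inhibition of CDK8/Cyclin C (Homo sapiens), with a stated time of 1 h, tested at 10 uM; on this read-out higher numbers stand for more inhibition at the one concentration tested (going by the name of the read-out) and lower numbers for less inhibition. Compound 1 gives 16%, the lower of the two values. Compound 2 gives 33%, a number that lies beyond the usual scatter above compound 1; the two structures differ in more than one place, so no single step can be read from that pair.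

The next compound, compound 3 `CNC(=O)COc1ccncc1-c1ccc2ccccc2c1`, keeps the core of compound 1 and changes only the chain end: methylamino in place of hydroxy on a carbonyl carbon. Among the measured compounds shown here, no measured pair in this set shows a change of this kind, so nothing says in which direction it moves the read-out in this assay.

Compound 3 is therefore expected near compound 1, with a step of a number 4 percentage points higher from compound 1 to compound 3 (within the scatter) that is estimated to stay within or only just beyond the scatter. The estimate for compound 3 in this assay is 20%, with a range from 5% to 40%.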

Compound 3, a percentage reported as inhibition, at one concentration (the size of the read-out at that concentration, not a potency): 4%
The estimate for compound 3 lay 16 percentage points above the measured number; measured number below the stated range.
By their numbers in this assay, from the lowest: compound 3; then compound 1; then compound 2.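

In this assay, among the compounds shown here, methylamino in place of hydroxy on a carbonyl carbon gives the first step that can be read in one place: a number 12 percentage points lower from compound 1 to compound 3 (beyond the scatter) with the core of compound 1 otherwise unchanged. The chain end is therefore not a silent position for this change, since replacing carboxy with methylcarbamoyl moves the read-out downward by a modest step, and of these two groups carboxy goes with the higher inhibition at the one concentration tested. No measurement on hand bears on the reason for this step.

Open, from the compounds shown here alone, is whether the step follows the loss of hydroxy or the arrival of the methyl on nitrogen, which an unsubstituted carbamoyl or a methyl ester at the same chain end would help to separate. Also open, going by these compounds, is whether the carboxy group keeps its edge on a longer chain, and whether this one step holds for other amines on the same carbonyl carbon, such as dimethylamino.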